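Extending the ketone chain in a glutamate receptor modulator series

A few compounds are considered here, and "the series" means these few. Any claim that something is new, unique, unknown or untested is made for them only; others in the source may bear on it.

Compound 1 `CCC(=O)c1ccc(OCCCCOc2ccc(F)c(C(=O)O)c2)c(C)c1O` is the reference point of this account. In an assay on HEK293 cells for positive allosteric modulation of metabotropic glutamate receptor 2 (Rattus norvegicus), read by thallium flux, with a stated time of 2.5 min (on this read-out higher numbers stand for larger maximal responses and lower numbers for smaller maximal responses), compound 1 gives 66.6%. Two related compounds set the frame. Compound 2 `COC(=O)c1ccc(OCCCCOc2ccc(C(=O)CC3CCCC3)c(C)c2C)cc1` gives 14.1% in this assay, and compound 3 `Cc1c(OCCCCOc2ccc(C(=O)O)c(Cl)c2)ccc(C(=O)CC2CCCC2)c1C` gives 61.8%. Within the data shown here, the one measured step, a number 47.7 percentage points higher from compound 2 to compound 3 (beyond the scatter), concerns the aryl group on the ether oxygen and not the ketone side. Against that frame, compound 1 stands far above compound 2, while its gap to compound 3 lies within the scatter, so the two cannot be ordered.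

The unmeasured compound 4 `Cc1c(OCCCCOc2ccc(F)c(C(=O)O)c2)ccc(C(=O)CC(C)C)c1O` differs from compound 1 in one place: isopropyl in place of methyl on a saturated chain carbon bound to a carbonyl carbon. Among the measured compounds shown here, no measured pair changes the saturated chain carbon bound to the carbonyl carbon, so the single step of this study does not bear on it directly. What the data do show is that compound 3, carrying a larger cyclopentyl group at that side, still reaches 61.8%, close to compound 1. On that basis a move from methyl to isopropyl is expected to leave the maximal response roughly where compound 1 has it, with no step beyond the scatter, as a number 3.6 percentage points lower from compound 1 to compound 4 (within the scatter) expresses. Compound 4 is therefore estimated at 63%, within a range from 46% to 80%.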

Compound 4, largest response reached (reported as percent of maximum), in percent of the reference or control that the assay uses: 84.5%
Compound 4: the middle estimate sits 21.5 percentage points below what was measured; measured number above the stated range.
By their numbers in this assay, from the lowest: compound 2; then compounds 3 and 1 (each within the scatter of the next); then compound 4.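

At the saturated chain carbon bound to a carbonyl carbon, the exchange of methyl for isopropyl can now be read directly, and in this assay it gives a number 17.9 percentage points higher from compound 1 to compound 4 (beyond the scatter) as its measured step. Among these compounds, the position therefore responds to the group it carries, a point that the earlier compounds could not settle, as none of their pairs changed this carbon. The change adds only carbon, with no ring, no hydrogen-bond donor or acceptor and no net charge, and nothing shown here accounts for the higher maximal response.

The compounds shown leave open how the response would run with a tert-butyl group or a longer chain such as n-butyl at this carbon, so a single step fixes neither a trend nor an upper limit for the position. They also leave open whether the same exchange would give a similar step with the 4-carboxy-3-chlorophenyl group of compound 3 on the ether oxygen, or with a carboxamide in place of the carboxylic acid.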